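This account rests on a few compounds, and the source may have more. Where it says the series, first, only, none or still open, it means among the compounds named here.

Working notes on the series in an in vitro functional assay on HEK293 cells for antagonist activity at melanin-concentrating hormone receptor 1 (Homo sapiens), read by GTPgammaS binding, with a stated time of 45 min; on this read-out higher numbers stand for higher potency (the scale is a negative logarithm) and lower numbers for lower potency. Compound 1 `Cc1ccc(CN2CCC(NC(=O)N(CC(=O)C(C)(C)O)Cc3ccc(-c4ccc(F)cc4)cc3)CC2)cc1` gives 5.34 in this assay. Compound 2 `COc1ccc(-c2ccc(CN(CC(=O)C(C)(C)O)C(=O)NC3CCN(Cc4ccc(C)cc4)CC3)cc2)cc1` gives < 5 in this assay, which is a limit of the assay and not a number; this is the limit of < 5 in this assay, at which 1 of the 3 values shown sits. The change from compound 1 to compound 2 is methoxy in place of fluoro on an aromatic carbon, and it brings a number at least 0.34 log units lower from compound 1 to compound 2 (beyond the scatter).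

Compound 3 `CC(=O)OCC(C)(C)NC(=O)N(CCC1CCN(Cc2ccc(C)cc2)CC1)Cc1ccc(-c2ccc(F)cc2)cc1` holds the higher of the two numbers in this assay, giving 6.39. The difference between the core of compound 3 and the core of compound 1 is not broken down here.

Compound 4 `COc1ccc(-c2ccc(CN(CCC3CCN(Cc4ccc(C)cc4)CC3)C(=O)NC(C)(C)COC(C)=O)cc2)cc1` has not yet been measured in this assay. It differs from compound 3 by methoxy in place of fluoro on an aromatic carbon, the same change as that from compound 1 to compound 2, at a place described in the same words. Within the data shown here, only one measured instance of the change exists, and its size is known only as a lower bound, so the size of the new step is open, while its direction is taken from the first pair. The step from compound 3 to compound 4 is expected to be a number 0.79 log units lower from compound 3 to compound 4 (beyond the scatter), resting on a number at least 0.34 log units lower from compound 1 to compound 2 (beyond the scatter). Compound 4 is accordingly estimated at 5.6 in this assay, with a range from 5 to 6.2 expected to cover most repeats. A result reported only as a limit would not be surprising for compound 4.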

Compound 4, negative logarithm of the antagonist equilibrium constant: 6.19
Compound 4: middle estimate off by 0.59 log units, on the low side, within the range that was stated.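

In this assay, among these compounds, going from 4-fluorophenyl to 4-methoxyphenyl on the core of compound 3 gives a number 0.20 log units lower from compound 3 to compound 4 (within the scatter), so on this core the hydrogen-bond acceptor that enters with the methoxy group brings no step that stands clear of repeat measurements. Two pairs on two cores do not establish that the change carries over from one core to the other with the same size, nor do they establish that the core alters its size: the same change on two cores in this assay, a number at least 0.34 log units lower (beyond the scatter) from compound 1 to compound 2 and a number 0.20 log units lower (within the scatter) from compound 3 to compound 4; the limit leaves it open whether they differ Compound 2 holds a limit of the assay and not a number, so the earlier step has a lower bound only and no exact size: the limit of < 5 in this assay, at which 1 of the 4 values shown sits.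

The compounds shown leave open how other groups at this place on the aromatic ring, such as chloro, a nitrile or an amine, would read on either core, and whether a third core would follow compound 3 and compound 4 or compound 1 and compound 2. They also leave open which of the several differences between the core of compound 1 and the core of compound 3 goes with the gap between their values, since no compound shown separates those differences.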